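The compounds below may be only part of what the source reports. "The series", "measured", "known", "first", "only" and "open" are said of these compounds alone.

Compound 3, `Cc1ccc(Nc2ncc3c(n2)N(c2ccccc2)C(=O)N(c2cc(NC(=O)c4ccc(C)c(C(F)(F)F)c4)ccc2C)C3)cn1`, is the compound whose number in an ADME assay on BaF3 cells (Mus musculus) for inhibition, read by CellTiter-Glo, with a stated time of 72 h (on this read-out higher numbers stand for weaker inhibition of growth and lower numbers for stronger inhibition of growth), is the higher of the two plain numbers shown, giving 3300 nM. The nearest is compound 2, `CCN1CCN(c2ccc(Nc3ncc4c(n3)N(C)C(=O)N(c3cc(NC(=O)c5cccc(C(F)(F)F)c5)ccc3C)C4)cn2)CC1`, which in this assay gives 264 nM, a gap that lies beyond the scatter. Compound 1, `Cc1ccc(Nc2ncc3c(n2)N(Cc2ccccc2)C(=O)N(c2cc(NC(=O)c4ccc(C)c(C(F)(F)F)c4)ccc2C)C3)cn1`, reaches only the limit of this assay, giving > 5000 nM, so it is a limit and not a number. Going by the values given here, the one step that has been measured within this set, an at least 1.5-fold lower number from compound 1 to compound 3 (0.18 log units; that floor lies within the scatter), runs from that limit and its floor lies within the scatter.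

Compound 4, `Cc1ccc(Nc2ncc3c(n2)N(C2CCCCC2)C(=O)N(c2cc(NC(=O)c4ccc(C)c(C(F)(F)F)c4)ccc2C)C3)cn1`, differs from compound 3 by cyclohexyl in place of phenyl on an amide-type nitrogen in a ring. Among the compounds with values here, the only measured step at the same position, an at least 1.5-fold lower number from compound 1 to compound 3 (0.18 log units; that floor lies within the scatter), is small, and no measured pair trades phenyl for cyclohexyl, so the change is expected to bring no step beyond the scatter. Compound 4 is therefore estimated at 3500 nM, within 1200 nM to 10000 nM, which means an expected step of a 1.1-fold higher number from compound 3 to compound 4 (0.03 log units; within the scatter).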

Compound 4, concentration for 50% growth inhibition: > 5000 nM
Compound 4: only a limit was reported; the forecaster's own chance of this, stated with the estimate: 25%; at least 1.4-fold (0.15 log units) between middle value and limit.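

In this assay compound 4 gives > 5000 nM, which is a limit and not a number. Trading the six-membered aromatic ring for the non-aromatic one, with the same count of heavy atoms, gives an at least 1.5-fold higher number from compound 3 to compound 4 (0.18 log units; that floor lies within the scatter), so the change brings no stronger inhibition of growth, although its true size remains unknown. The step from compound 1 to compound 4 cannot be read, and cyclohexyl and benzyl cannot be ordered on this nitrogen: the limit of > 5000 nM in this assay, at which 2 of the 4 values shown sit.

On these data alone, what an ethyl group, a longer chain ending in an amine, or a pyridine ring would give on this nitrogen, with the rest of compound 3 kept, stays open. Compound 2 differs from the others in more than one place, so its value cannot settle this.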